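Aryl swaps on the shared core: toward compound 4

A few compounds are considered here, and "the series" means these few. Any claim that something is new, unique, unknown or untested is made for them only; others in the source may bear on it.

Measured so far:
compound 1 `N#CC1=C(N)N(c2ccc(S(N)(=O)=O)cc2)C2=C(C(=O)CCC2)C1c1ccc(O)cc1` — 90%
compound 2 `COc1ccc(C2C(C#N)=C(N)N(c3ccc(S(N)(=O)=O)cc3)C3=C2C(=O)CCC3)cc1` — 30%
compound 3 `N#CC1=C(N)N(c2ccc(S(N)(=O)=O)cc2)C2=C(C(=O)CCC2)C1c1cccc([N+](=O)[O-])c1` — 42%

In a functional assay on Ehrlich cells (Mus musculus) for antiproliferative activity, read by trypan blue exclusion, with a stated time of 2 h, tested at 10 ug/mL (on this read-out lower numbers stand for a weaker effect and higher numbers for a stronger effect at the one concentration tested), compound 2 stands lowest of the three: compound 3 lies nearest, compound 1 furthest. Compound 4 `N#CC1=C(N)N(c2ccc(S(N)(=O)=O)cc2)C2=C(C(=O)CCC2)C1c1ccc(Cl)cc1Cl` differs from compound 2 by 2,4-dichlorophenyl in place of 4-methoxyphenyl on a saturated ring carbon. Within the data shown here, two measured steps bear on a swap of the aryl group on a saturated ring carbon: a number 12 percentage points higher from compound 2 to compound 3 (beyond the scatter) and a number 48 percentage points lower from compound 1 to compound 3 (beyond the scatter); the step of a number 60 percentage points lower from compound 1 to compound 2 (beyond the scatter) shows how strongly the group there can move this assay. Among the measured compounds shown here, no measured compound carries the entering group, so the direction remains open. A modest step up from compound 2 is expected, a number 10 percentage points higher from compound 2 to compound 4 (within the scatter). Compound 4 is estimated at 40%, within 20% to 65%.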

Compound 4, a percentage reported as activity, at one concentration (the size of the read-out at that concentration, not a potency): 40%
Beside the measured number, compound 4's estimate shows no gap at the digits printed; the range from low to high includes it.
By their numbers in this assay, from the lowest: compounds 2, 4 and 3 (each within the scatter of the next, the first and the last beyond it); then compound 1.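

In this assay, 2,4-dichlorophenyl on the saturated ring carbon shows a number 10 percentage points higher from compound 2 to compound 4 (within the scatter) and a number 2 percentage points lower from compound 3 to compound 4 (within the scatter), so this chlorinated aryl group is not separated from either 4-methoxyphenyl or 3-nitrophenyl. The 4-hydroxyphenyl group of compound 1 remains apart from this new group, with a number 50 percentage points lower from compound 1 to compound 4 (beyond the scatter), and a third kind of substituted aryl group does not close that gap. Nothing measured here gives a reason for these differences.

From the compounds shown here alone, whether 4-aminophenyl or 4-carboxyphenyl at this carbon would stay near compound 1 remains open. Going by these compounds, a plain phenyl group at this carbon also remains open as a reference point.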